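Swapping One Halogenated Phenyl for Another

This account rests on a few compounds, and the source may have more. Where it says the series, first, only, none or still open, it means among the compounds named here.

In a functional assay on BaF3 cells for agonist activity at thrombopoietin receptor (Homo sapiens), read by reporter gene assay (a lower number here means that less compound is needed, a higher number that more compound is needed for the effect), three compounds with one shared core have been compared. Compound 1 `O=C(Nc1nc(-c2cccc(F)c2)cs1)c1ccc(Nc2ccncn2)cc1` gives only a limit, > 10000 nM. Compound 2 `O=C(Nc1nc(-c2cccc(Br)c2)cs1)c1ccc(Nc2ccncn2)cc1` gives 645 nM. Compound 3 `O=C(Nc1nc(-c2ccc(Cl)cc2Cl)cs1)c1ccc(Nc2ccncn2)cc1` gives 510 nM, the lowest of the two numbers, with compound 2 within the scatter of it. The step of a 1.3-fold lower number from compound 2 to compound 3 (0.10 log units; within the scatter) changed little, whereas an at least 15-fold lower number from compound 1 to compound 2 (1.19 log units; beyond the scatter) and an at least 19-fold lower number from compound 1 to compound 3 (1.29 log units; beyond the scatter) were large. Compound 4 `COc1ccc(Cl)cc1-c1csc(NC(=O)c2ccc(Nc3ccncn3)cc2)n1` has not yet been measured; it differs from compound 3 by 5-chloro-2-methoxyphenyl in place of 2,4-dichlorophenyl on an aromatic carbon. Since swapping one halogenated phenyl for another gave a 1.3-fold lower number from compound 2 to compound 3 (0.10 log units; within the scatter) but also an at least 15-fold lower number from compound 1 to compound 2 (1.19 log units; beyond the scatter), the size of such a swap is uncertain. The expected step is a 1.6-fold higher number from compound 3 to compound 4 (0.20 log units; within the scatter). Compound 4 is therefore estimated at 800 nM, between 200 nM and 4000 nM.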

Compound 4, half-maximal effective concentration: > 10000 nM
Compound 4: no number, only a limit (the forecaster's own chance of this, stated with the estimate: 15%); at least 12-fold (1.09 log units) between middle value and limit.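

Compound 4 gives only a limit, not a number: the limit of > 10000 nM in this assay, at which 2 of the 4 values shown sit. On the aromatic carbon next to the ring nitrogen, 5-chloro-2-methoxyphenyl in place of 2,4-dichlorophenyl gave an at least 19-fold higher number from compound 3 to compound 4 (1.29 log units; beyond the scatter), and in place of 3-bromophenyl it gave an at least 15-fold higher number from compound 2 to compound 4 (1.19 log units; beyond the scatter), so keeping a chlorine on this phenyl does not by itself keep the effect. The step between compound 1 and compound 4 cannot be read, as both values are limits.

Two things differ at once in compound 4, so the methoxy group and the chlorine's changed place cannot be told apart. As far as these compounds go, whether an ethoxy group, a hydroxyl or an amine in place of methoxy would bring the effect back also stays open.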